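The source may report more compounds than this note shows. Statements on the series, on what has been measured and on what is new or still open speak of the compounds shown alone.

Three compounds of this series have numbers in a functional assay on HOS-TE85 cells (Homo sapiens) for inhibition, read by CCK-8 assay, with a stated time of 72 h; on this read-out lower numbers stand for stronger inhibition and higher numbers for weaker inhibition. Compound 1 `COc1c(F)cccc1N1C(=O)CSC1c1cccc(C(=O)NCCCCc2ccccc2)c1` gives 26.2 nM, compound 2 `O=C(NCCCCc1ccccc1)c1cccc(C2SCC(=O)N2c2ccccc2)c1` gives 15.9 nM, and compound 3 `COc1ccc(F)cc1N1C(=O)CSC1c1cccc(C(=O)NCCCCc2ccccc2)c1` gives 8.8 nM. Going by the values given here, compound 3 carries the lowest of the three numbers, yet its nearest neighbour is compound 2 at a gap within the scatter, so no ranking between these two is warranted; the only step beyond the scatter is a 3.0-fold lower number from compound 1 to compound 3 (0.47 log units; beyond the scatter), a modest one. The two other single-point steps are small: a 1.6-fold lower number from compound 1 to compound 2 (0.22 log units; within the scatter) and a 1.8-fold lower number from compound 2 to compound 3 (0.26 log units; within the scatter).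

Compound 4 `Cc1cccc(N2C(=O)CSC2c2cccc(C(=O)NCCCCc3ccccc3)c2)c1` is not yet measured. It differs from compound 3 in one place: 3-methylphenyl in place of 5-fluoro-2-methoxyphenyl on an amide-type nitrogen in a ring. Among the compounds with values here, no measured step introduces a methyl on this group, so the step has to be read from the exchanges already seen on the amide-type nitrogen in the ring. Both swaps that touch this group, a 1.6-fold lower number from compound 1 to compound 2 (0.22 log units; within the scatter) and a 1.8-fold lower number from compound 2 to compound 3 (0.26 log units; within the scatter), stayed within the scatter, and compound 2 with a plain phenyl there sits close to compound 3. For compound 4 the step expected in this assay is therefore small, a 1.8-fold higher number from compound 3 to compound 4 (0.26 log units; within the scatter), with no direction beyond the scatter. Compound 4 is estimated at 16 nM, with a range of 6 nM to 40 nM.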

Compound 4, half-maximal inhibitory concentration in the HOS-TE85 assay: 93.2 nM
Beside the measured number, compound 4's estimate is 5.8-fold (0.77 log units) below it; the measured number lies above the stated range.
By their numbers in the HOS-TE85 assay, from the lowest: compounds 3, 2 and 1 (each within the scatter of the next, the first and the last beyond it); then compound 4.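

In the HOS-TE85 assay, the earlier exchanges on the amide-type nitrogen in the ring gave only small or modest steps, whereas the 3-methylphenyl group brings the first large one, an 11-fold higher number from compound 3 to compound 4 (1.02 log units; beyond the scatter), and it also stands apart from the other two compounds, with a 5.9-fold higher number from compound 2 to compound 4 (0.77 log units; beyond the scatter) and a 3.6-fold higher number from compound 1 to compound 4 (0.55 log units; beyond the scatter). The step from the plain phenyl is a single exchange, methyl in place of hydrogen on an aromatic carbon, so this position is shown to respond to a change as limited as one methyl, although phenyl and the two fluoro-methoxyphenyl groups had not suggested it. In a physicochemical assay for solubility, read by turbidimetry, measured as kinetic solubility, at pH 7.4 (a higher number here means a more soluble compound, a lower number a less soluble compound), compound 3 gives 10000 nM and compound 4 gives 10000 nM, so among these two the exchange separates the compounds only in the HOS-TE85 assay.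

Nothing at hand gives a reason for the weaker inhibition seen with the methyl group. From the compounds shown here alone, it also remains open whether a chlorine atom, a hydroxyl or an amine in place of that methyl on the phenyl ring would give numbers closer to those of compound 2 or to that of compound 4.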